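Swapping a Nitrophenyl Tail for Thiophene on a Nucleotide

The source may hold more compounds than are shown below. What is called first, only, known or untested is meant among the compounds shown, and "the series" means these compounds.

Two compounds share the same triphosphate nucleotide core and differ only in the aromatic tail at the end of the side chain. Compound 1 `O=c1[nH]/c(=N\OCCOc2ccccc2)ccn1[C@@H]1O[C@H](COP(=O)(O)OP(=O)(O)OP(=O)(O)O)[C@@H](O)[C@H]1O` carries a phenoxy group, and in a functional assay on 1321-N1 cells for agonist activity at P2Y purinoceptor 2 (Homo sapiens), read by scintillation counting and inositol phosphate accumulation (a higher number here means that more compound is needed for the effect, a lower number that less compound is needed), compound 1 gives 3400 nM. Compound 2 `O=c1[nH]/c(=N\OCCCc2cccc([N+](=O)[O-])c2)ccn1[C@@H]1O[C@H](COP(=O)(O)OP(=O)(O)OP(=O)(O)O)[C@@H](O)[C@H]1O` carries a 3-nitrobenzyl group instead, and in this assay compound 2 gives 457 nM. For the measured compounds named here, that is a 7.4-fold lower number from compound 1 to compound 2 (0.87 log units; beyond the scatter), so compound 2 stands at the lower of the two numbers measured so far. Compound 3 `O=c1[nH]/c(=N\OCCCc2ccsc2)ccn1[C@@H]1O[C@H](COP(=O)(O)OP(=O)(O)OP(=O)(O)O)[C@@H](O)[C@H]1O` keeps everything of compound 2 except the tail: thiophen-3-yl in place of 3-nitrophenyl on a saturated chain carbon, three bonds along the chain from an oxygen. Going by the values given here, no measured step exchanges one aromatic ring for another on an otherwise unchanged chain; the only step available, from compound 1 to compound 2, shows that this tail region can move the number well beyond the scatter, but it gives no direction for a thiophene. Since the change removes the group whose arrival brought a 7.4-fold lower number from compound 1 to compound 2 (0.87 log units; beyond the scatter), compound 3 is expected to give a somewhat higher number, a 3.3-fold higher number from compound 2 to compound 3 (0.52 log units; beyond the scatter), with wide uncertainty. The estimate for compound 3 in this assay is 1500 nM, with a range from 300 nM to 7000 nM.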

Compound 3, half-maximal effective concentration: 103 nM
Compound 3: the middle estimate sits 15-fold (1.16 log units) above what was measured; the whole stated range lies above it.
By their numbers in this assay, from the lowest: compound 3; then compound 2; then compound 1.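

Going from a nitro-bearing ring to a thiophene ring does not cost activity at this position: in this assay, thiophen-3-yl in place of 3-nitrophenyl gives a 4.4-fold lower number from compound 2 to compound 3 (0.65 log units; beyond the scatter). The 3-nitrophenyl group is therefore not needed for a low number here, and a tail with fewer heavy atoms and a five-membered ring can go further than the nitro-bearing tail did. Against the phenoxy tail, the (thiophen-3-yl)methyl tail gives a 33-fold lower number from compound 1 to compound 3 (1.52 log units; beyond the scatter), the largest step among these three compounds, which shows how much this end of the side chain can shift the number; no measurement here explains why the thiophene does better.

The three compounds do not separate the effect of losing the nitro group from that of gaining the sulfur-containing ring, and a plain phenyl or a furan ring on the same chain would speak to that directly. From the compounds shown here alone, it also remains open whether a longer chain, or an amine or carboxylic acid on the ring, would move the number further in either direction.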